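The source may hold more compounds than are shown below. What is called first, only, known or untested is meant among the compounds shown, and "the series" means these compounds.

Compound 2 `COc1ncc(-c2ccc3ncnc(Nc4cnn(CCCO)c4)c3c2)cc1NS(=O)(=O)c1ccc(F)cc1F` gives 1310 nM in a functional assay on MCF7 cells (Homo sapiens) for antiproliferative activity, read by sulforhodamine B assay, with a stated time of 72 h; on this read-out higher numbers stand for weaker inhibition and lower numbers for stronger inhibition. Compound 1 `COc1ncc(-c2ccc3ncnc(Nc4ccc(OCCO)cc4)c3c2)cc1NS(=O)(=O)c1ccc(F)cc1F` gives 1650 nM in this assay; the step is a 1.3-fold higher number from compound 2 to compound 1 (0.10 log units; within the scatter), and the change behind it is 4-(2-hydroxyethoxy)phenyl in place of 1-(3-hydroxypropyl)-1H-pyrazol-4-yl on a nitrogen on an aromatic ring. Compound 3 `COc1ncc(-c2ccc3ncnc(Nc4cnn(CCCO)c4)c3c2)cc1NS(C)(=O)=O` gives 730 nM in this assay; here the step is a 1.8-fold lower number from compound 2 to compound 3 (0.25 log units; within the scatter), and the change is methyl in place of 2,4-difluorophenyl on a sulfonyl sulfur. Compound 4 `COc1ncc(-c2ccc3ncnc(Nc4ccc(OCCO)cc4)c3c2)cc1NS(C)(=O)=O` has not yet been measured. It differs from compound 3 by 4-(2-hydroxyethoxy)phenyl in place of 1-(3-hydroxypropyl)-1H-pyrazol-4-yl on a nitrogen on an aromatic ring; this is the same change as that from compound 2 to compound 1, made on the same place, while the two cores differ by methyl in place of 2,4-difluorophenyl on a sulfonyl sulfur. Within the data shown here, the earlier step of a 1.3-fold higher number from compound 2 to compound 1 (0.10 log units; within the scatter) is the only guide available. The step from compound 3 to compound 4 is expected to be of similar size, a 1.3-fold higher number from compound 3 to compound 4 (0.11 log units; within the scatter). Compound 4 is therefore estimated at 950 nM in this assay, with a range from 500 nM to 1900 nM.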

Compound 4, half-maximal inhibitory concentration: 3270 nM
Beside the measured number, compound 4's estimate is 3.4-fold (0.54 log units) below it, outside the stated range (above it).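

In this assay the change to 4-(2-hydroxyethoxy)phenyl gives a 4.5-fold higher number from compound 3 to compound 4 (0.65 log units; beyond the scatter), and it does not carry over at the same size from the core of compound 2: the same change on two cores in this assay, a 1.3-fold higher number (0.10 log units; within the scatter) from compound 2 to compound 1 and a 4.5-fold higher number (0.65 log units; beyond the scatter) from compound 3 to compound 4, 3.6-fold (0.55 log units) apart, beyond the scatter of two such steps

Methyl in place of 2,4-difluorophenyl on a sulfonyl sulfur gives a 2.0-fold higher number from compound 1 to compound 4 (0.30 log units; within the scatter), and this change too does not read the same on the two cores: the same change on two cores in this assay, a 1.8-fold lower number (0.25 log units; within the scatter) from compound 2 to compound 3 and a 2.0-fold higher number (0.30 log units; within the scatter) from compound 1 to compound 4, 3.6-fold (0.55 log units) apart, beyond the scatter of two such steps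

These four compounds show that the two changes do not add up independently here, but they do not show why, nor whether this holds on any other core.

Going by these compounds, it stays open whether the gap recurs with other groups on the sulfonyl sulfur, such as ethyl or phenyl. On these data alone, it also stays open how a pyrazolyl group carrying an amine or a carboxylic acid in place of the hydroxypropyl chain would behave.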